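The source may report more compounds than this note shows. Statements on the series, on what has been measured and on what is new or still open speak of the compounds shown alone.

Working notes on the series. Compound 1 `Cn1c(=O)c(=O)n(C2CCCC2)c2nc(N/N=C/c3ccccc3)ncc21` carries an unsubstituted phenyl on a carbon with a double bond to nitrogen. In a functional assay on HCT-116 cells (Homo sapiens) for antiproliferative activity, read by MTT assay (on this read-out lower numbers stand for stronger inhibition and higher numbers for weaker inhibition), compound 1 gives > 100000 nM, which is a limit of the assay and not a number (the limit of > 100000 nM in this assay, at which 1 of the 3 values shown sits). Compound 2 `Cn1c(=O)c(=O)n(C2CCCC2)c2nc(N/N=C/c3ccc(C(F)(F)F)cc3)ncc21` gives 29000 nM in this assay, and compound 3 `Cn1c(=O)c(=O)n(C2CCCC2)c2nc(N/N=C/c3cccc(Cl)c3Cl)ncc21` gives 26400 nM. Both substituted compounds lie clear of compound 1: there is an at least 3.4-fold lower number from compound 1 to compound 2 (0.53 log units; beyond the scatter), with trifluoromethyl in place of hydrogen on an aromatic carbon, and an at least 3.7-fold lower number from compound 1 to compound 3 (0.57 log units; beyond the scatter). Between the two substituted compounds there is only a 1.1-fold lower number from compound 2 to compound 3 (0.04 log units; within the scatter).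

Compound 4 `Cc1ccc(/C=N/Nc2ncc3c(n2)n(C2CCCC2)c(=O)c(=O)n3C)cc1C` is not yet measured. It differs from compound 1 as follows: 3,4-dimethylphenyl in place of phenyl on a carbon with a double bond to nitrogen. Among the compounds with values here, the steps that bear on it are the two from compound 1 to a substituted phenyl, both at least modest and both toward lower numbers. The change to compound 4 is of the same kind, 3,4-dimethylphenyl in place of phenyl on a carbon with a double bond to nitrogen, though with other substituents than those already tried. Since compound 1 stands only at a limit, the true size of any step from it is uncertain. A downward step of similar size in this assay is therefore expected, an at least 2.5-fold lower number from compound 1 to compound 4 (0.39 log units; beyond the scatter). Compound 4 is estimated at 40000 nM, expected to fall between 15000 nM and 110000 nM.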

Compound 4, half-maximal inhibitory concentration: 62900 nM
Beside the measured number, compound 4's estimate is 1.6-fold (0.20 log units) below it; the measured number falls inside the stated range.
By their numbers in this assay, from the lowest: compounds 3 and 2 (each within the scatter of the next); then compound 4. At a limit, above all of these: compound 1.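

In this assay, 3,4-dimethylphenyl in place of phenyl on a carbon with a double bond to nitrogen gives an at least 1.5-fold lower number from compound 1 to compound 4 (0.20 log units; that floor lies within the scatter), so this change, unlike the two earlier changes at this place, is not shown to lower the number beyond the scatter, and the figure is only a floor because compound 1 stands at a limit and not at a number: the limit of > 100000 nM in this assay, at which 1 of the 4 values shown sits.

Within the data shown here, the substituted phenyls also separate for the first time, with a 2.4-fold higher number from compound 3 to compound 4 (0.38 log units; beyond the scatter) and a 2.2-fold higher number from compound 2 to compound 4 (0.34 log units; beyond the scatter), whereas compound 2 and compound 3 had stayed within the scatter of each other. At this place, then, the read-out depends on which substituents the phenyl carries and not merely on the presence of substituents, with compound 4 going against any reading that all substitution of the phenyl acts alike.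

The compounds shown leave open how far a single methyl or a single chlorine on the phenyl would account for these differences. They also leave open how a phenyl bearing a methoxy group, an amine or a carboxylic acid would stand in this assay, and what the true size of any step from compound 1 is.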